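From 3-methylbenzyl to 2-methoxybenzyl on the shared core

The source may report more compounds than this note shows. Statements on the series, on what has been measured and on what is new or still open speak of the compounds shown alone.

Measured so far in a functional assay on CCRF-CEM cells (Homo sapiens) for antiproliferative activity, with a stated time of 72 h; on this read-out lower numbers stand for stronger inhibition and higher numbers for weaker inhibition:
- compound 1 `OC[C@H]1O[C@@H](n2cnc3c(NCc4ccccc4Br)ncnc32)[C@H](O)[C@@H]1O` gives 12300 nM
- compound 2 `Cc1cccc(CNc2ncnc3c2ncn3[C@@H]2O[C@H](CO)[C@@H](O)[C@H]2O)c1` gives 19100 nM

Compound 2 gives 19100 nM and compound 1 gives 12300 nM within the scatter of each other. In compound 3 `COc1ccccc1CNc1ncnc2c1ncn2[C@@H]1O[C@H](CO)[C@@H](O)[C@H]1O` the change is 2-methoxyphenyl in place of 3-methylphenyl on a saturated chain carbon bound to a nitrogen on an aromatic ring with 2-methoxyphenyl in place of 3-methylphenyl. Among the measured compounds shown here, only one measured step bears on this, a phenyl exchange at the same place, and it was small: a 1.6-fold higher number from compound 1 to compound 2 (0.19 log units; within the scatter) is all it moved. No step beyond the scatter is therefore expected in this assay and the estimated step is a 1.3-fold lower number from compound 2 to compound 3 (0.10 log units; within the scatter) in size. Compound 3 is estimated at 15000 nM with a range from 6000 nM to 35000 nM expected.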

Compound 3, half-maximal inhibitory concentration: 3200 nM
Estimate against measurement, compound 3: 4.7-fold (0.67 log units) above; the whole stated range lies above it.
By their numbers in this assay, from the lowest: compound 3; then compounds 1 and 2 (each within the scatter of the next).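

In this assay the aryl group on this saturated chain carbon turns out to matter more than the first exchange suggested: 2-methoxyphenyl in place of 3-methylphenyl gives a 6.0-fold lower number from compound 2 to compound 3 (0.78 log units; beyond the scatter) and methoxy in place of bromo on an aromatic carbon gives a 3.8-fold lower number from compound 1 to compound 3 (0.58 log units; beyond the scatter) as well. Both steps lie beyond the scatter and both end at compound 3, so among these compounds only the entry of methoxy moves the number. Nothing available here accounts for this. From the compounds shown here alone, whether an ethoxy group or an amine in place of the methoxy would do the same stays open.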